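The compounds below may be only part of what the source reports. "The series", "measured", "known", "first", "only" and "open" are said of these compounds alone.

Measured compounds:
- compound 1, `C=C/C=C\[C@H](C)[C@H](OC(N)=O)[C@@H](C)[C@H](O)[C@@H](C)C/C(C)=C\[C@H](C)[C@@H](O)[C@@H](C)/C=C\CCc1cccc(F)c1`: 370 nM in a functional assay on MCF7 cells (Homo sapiens) for cytotoxicity; a higher number here means a weaker inhibitor, a lower number a stronger inhibitor
- compound 2, `C=C/C=C\[C@H](C)[C@H](OC(N)=O)[C@@H](C)[C@H](O)[C@@H](C)C/C(C)=C\[C@H](C)[C@@H](O)[C@@H](C)/C=C\CCc1cc(F)cc(F)c1`: 600 nM in this assay

Compound 1 holds the lowest of the two numbers in this assay; its nearest neighbour is compound 2, and the step of a 1.6-fold higher number from compound 1 to compound 2 (0.21 log units; within the scatter) is within the scatter, so the two values cannot be ordered.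

Compound 3, `C=C/C=C\[C@H](C)[C@H](OC(N)=O)[C@@H](C)[C@H](O)[C@@H](C)C/C(C)=C\[C@H](C)[C@@H](O)[C@@H](C)/C=C\CCc1cc(O)cc(O)c1`, is not yet measured. Against compound 1 it carries the change (3,5-dihydroxyphenyl in place of 3-fluorophenyl on a saturated chain carbon, two bonds along the chain from a double-bonded chain carbon).

Within the data shown here, the only measured step, a 1.6-fold higher number from compound 1 to compound 2 (0.21 log units; within the scatter), concerns a fluoro in place of hydrogen on an aromatic carbon and stays within the scatter. Among the measured compounds shown here, it shows that one added substituent on that ring was tolerated, but no measured step exchanges the fluorine for hydroxyl or introduces hydrogen-bond donors on the ring, so the present change has no direct precedent. The expectation for compound 3 in this assay is therefore drawn wide, centred on a modest weakening: the estimated step is a 2.0-fold higher number from compound 1 to compound 3 (0.31 log units; beyond the scatter). Compound 3 is expected to give 750 nM, with a range from 200 nM to 2800 nM.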

Compound 3, half-maximal inhibitory concentration: 160 nM
Compound 3: middle estimate off by 4.7-fold (0.67 log units), on the high side; measured number below the stated range.
By their numbers in this assay, from the lowest: compound 3; then compounds 1 and 2 (each within the scatter of the next).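

In this assay, this position now responds to a change on the ring: 3,5-dihydroxyphenyl in place of 3-fluorophenyl gives a 2.3-fold lower number from compound 1 to compound 3 (0.36 log units; beyond the scatter), and 3,5-dihydroxyphenyl in place of 3,5-difluorophenyl gives a 3.8-fold lower number from compound 2 to compound 3 (0.57 log units; beyond the scatter). The earlier fluoro step stayed within the scatter and so could show only that a second fluorine was tolerated, whereas both new steps lie beyond the scatter and run in the same direction, leaving compound 3 with the lowest number among the three compounds and showing that a ring with hydrogen-bond donors is accepted here in this cell read-out. No supporting measurement bears on why the number falls.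

The compounds shown leave open whether both hydroxyl groups are needed or a ring with a single hydroxyl would give a similar number, and whether methoxy groups or amines in place of the hydroxyls would keep the lower number. They also leave open whether the gain depends on the two-carbon link to the ring, which a longer chain carrying the same 3,5-dihydroxyphenyl group would test.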